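The source may report more compounds than this note shows. Statements on the series, on what has been measured and on what is new or still open speak of the compounds shown alone.

The compounds share one core, and in an assay on HEK293 cells for positive allosteric modulation of metabotropic glutamate receptor 5 (Homo sapiens), read by FLIPR, with a stated time of 1 h (on this read-out higher numbers stand for an effect only at larger amounts of compound and lower numbers for an effect already at smaller amounts), only compound 2, with the structure `CC1CCCC(C(=O)N2CCc3nc(C#Cc4ccccc4)sc3C2)C1`, gives a number: compound 2 reaches 100 nM. Compound 1, with the structure `CCN1CCc2nc(C#Cc3ccccc3)sc2C1`, gives only a limit in this assay: compound 1 shows > 10000 nM. The other value shown is therefore (the limit of > 10000 nM in this assay, at which 1 of the 2 values shown sits). Among the compounds with values here, compound 2 thus holds the only measured number among the two, and no step between measured compounds is available. Compound 1 and compound 2 differ in more than one place. Compound 3, with the structure `Cc1nc(C(=O)N2CCc3nc(C#Cc4ccccc4)sc3C2)cs1`, has not been measured yet. It differs from compound 2 in one place: 2-methyl-1,3-thiazol-4-yl in place of 3-methylcyclohexyl on a carbonyl carbon. Without a measured step to gauge this exchange, the expectation rests on compound 2 alone, and an amide of a small aromatic heterocycle in place of an amide of a saturated ring is expected to change the number only modestly, if at all beyond the scatter. This exchange is expected to give a 2.0-fold higher number from compound 2 to compound 3 (0.30 log units; within the scatter). For compound 3 the expected value in this assay is 200 nM, with a range from 50 nM to 1500 nM.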

Compound 3, half-maximal effective concentration: 220 nM
For compound 3 the middle estimate is 1.1-fold (0.04 log units) below the measured one; low and high end bracket the measured number.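

In this assay, the place on the carbonyl carbon accepts more than one kind of ring: 2-methyl-1,3-thiazol-4-yl in place of 3-methylcyclohexyl gives a 2.2-fold higher number from compound 2 to compound 3 (0.34 log units; beyond the scatter), a modest step. A saturated ring of carbon only is therefore not required there for a measurable effect, and a five-membered aromatic ring with 2 hetero atoms also gives a number, though a somewhat higher one. The new compound also gives the first single-place comparison with the ethyl compound, where (2-methyl-1,3-thiazol-4-yl)carbonyl in place of ethyl on an amine nitrogen in a ring gives an at least 45-fold lower number from compound 1 to compound 3 (1.65 log units; beyond the scatter), and this large step starts from a limit rather than a number, the one held by compound 1: the limit of > 10000 nM in this assay, at which 1 of the 3 values shown sits.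

With only two rings shown on the carbonyl carbon, it remains open how much the ring itself contributes, and whether a plain phenyl, a pyridine or a short alkyl chain such as propyl would give a similar number. On these data alone, it also remains open what the methyl on the thiazole adds, and whether a simple acetyl group on the amine nitrogen would already give a number.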